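From Iodo to Phenoxy: What Compound 4 Might Need

A few compounds are considered here, and "the series" means these few. Any claim that something is new, unique, unknown or untested is made for them only; others in the source may bear on it.

Of the compounds shown here, three built on one shared core have been tested in a functional assay on the whole organism with Mus musculus as the target, in the maximal electroshock model, with a stated time of 30 min; on this read-out lower numbers stand for an effect already at smaller amounts and higher numbers for an effect only at larger amounts of compound. Compound 1 `CC(C)c1ccccc1NC(=O)Nc1ccncc1` gives 100 mg/kg in this assay. Compound 2 `O=C(Nc1ccncc1)Nc1ccccc1O` reaches only a limit of the assay, > 300 mg/kg. Compound 3 `O=C(Nc1ccncc1)Nc1ccc(I)cc1` likewise reaches only a limit of the assay, > 300 mg/kg. Among the compounds with values here, the one measured step, an at least 3.0-fold higher number from compound 1 to compound 2 (0.47 log units; beyond the scatter), shows that a single change on the aromatic ring can move a compound from a clear dose to no effect in the tested range. Two of the three compounds therefore sit at the limit of > 300 mg/kg in this assay, at which 2 of the 3 values shown sit.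

Compound 4 `O=C(Nc1ccncc1)Nc1ccc(Oc2ccccc2)cc1` differs from compound 3 in one place: phenoxy in place of iodo on an aromatic carbon. Within the data shown here, no measured step involves iodo or phenoxy, so the single measured step, which concerns a different pair of groups, gives only indirect guidance. On these data alone, because compound 3 shows only a limit, its true dose is unknown, and the estimate for compound 4 must be wide. Compound 4 is expected to give about 300 mg/kg, somewhere between 100 mg/kg and 1000 mg/kg. The expected step is a number no higher from compound 3 to compound 4 (the limit leaves the size open), with a real chance that only a limit is reported again.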

Compound 4, minimum effective dose: > 300 mg/kg
Compound 4: no number, only a limit (the forecaster's own chance of this, stated with the estimate: 55%); the middle value lies on the limit itself.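

Compound 3 and compound 4 both reach only a limit, so no step between them can be read: the limit of > 300 mg/kg in this assay, at which 3 of the 4 values shown sit.

The compounds shown leave open whether phenoxy and iodo differ at all in this read-out, and what dose, if any, would show an effect for either compound.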